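The compounds below may be only part of what the source reports. "The series", "measured", "known", "first", "only" and "open" are said of these compounds alone.

The series shares one core, varied only at the amine nitrogen. Compound 1 `Cc1ccc(NC2=CC(=O)c3c(nc4n3[C@H]3OC[C@@H](O)[C@H]3OC4)C2=O)cc1C` carries a 3,4-dimethylphenyl on that nitrogen; in a functional assay on MGC-803 cells (Homo sapiens) for inhibition, read by sulforhodamine B assay (on this read-out higher numbers stand for weaker inhibition and lower numbers for stronger inhibition), compound 1 gives 1050 nM, the lowest of the two numbers recorded so far. Compound 3 `CCOc1ccccc1NC1=CC(=O)c2nc3n(c2C1=O)[C@H]1OC[C@@H](O)[C@H]1OC3`, with a 2-ethoxyphenyl on the amine nitrogen, gives 2450 nM in this assay; the two values differ by more than the scatter, with compound 1 ahead. Compound 2 `O=C1C=C(NC2CCCC2)C(=O)c2c1nc1n2[C@H]2OC[C@@H](O)[C@H]2OC1`, which carries a cyclopentyl, reaches only a limit of the assay, > 8000 nM in this assay, (the limit of > 8000 nM in this assay, at which 1 of the 3 values shown sits). Among the compounds with values here, the single step measured in one place is an at least 3.2-fold lower number from compound 2 to compound 3 (0.51 log units; beyond the scatter), which shows an aromatic group on the amine nitrogen doing at least modestly better than the saturated ring; compound 1 and compound 3 are the only aromatic cases, and the three compounds allow no wider pattern.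

Compound 4 `O=C1C(Nc2cccc(F)c2)=CC(=O)c2c1nc1n2[C@H]2OC[C@@H](O)[C@H]2OC1`, not yet measured, differs from compound 1 by 3-fluorophenyl in place of 3,4-dimethylphenyl on an amine nitrogen. Within the data shown here, no measured step covers an exchange of one aromatic group for another. The two aryl cases, compound 1 and compound 3, stand apart beyond the scatter, so some movement between aryl groups is plausible. Compound 4 is expected to remain with the aryl amines, a step of a 1.7-fold higher number from compound 1 to compound 4 (0.23 log units; within the scatter) toward a somewhat higher number in this assay. Compound 4 is therefore estimated at 1800 nM, within 800 nM to 4500 nM.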

Compound 4, half-maximal inhibitory concentration: 1470 nM
Beside the measured number, compound 4's estimate is 1.2-fold (0.09 log units) above it; measured number inside the range.
By their numbers in this assay, from the lowest: compounds 1, 4 and 3 (each within the scatter of the next, the first and the last beyond it). At a limit, above all of these: compound 2.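

In this assay, within the data shown here, the exchange on the amine nitrogen gives a 1.4-fold higher number from compound 1 to compound 4 (0.15 log units; within the scatter), the only measured exchange of one aryl group for another, and it stays within the scatter. On this read-out, 3-fluorophenyl and 3,4-dimethylphenyl therefore cannot be told apart, so this position accepts a fluorine-bearing aryl group in place of a dimethyl-substituted one with no readable change, and compound 4 joins compound 1 as a second aryl amine with a value in the same range. Nothing at hand gives a cause for this near-equality, so the step stands as an observation only.

The step exchanges the whole aryl group, so the separate contributions of the fluorine and of each methyl group cannot be read from it, and a plain phenyl or a 3-methylphenyl would be needed to separate them. Also open, on these data alone, is how this nitrogen responds to a 3-chlorophenyl, to an aryl group carrying a carboxylic acid or a dimethylamino group, or to a benzyl group or a longer open alkyl chain.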